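The compounds below may be only part of what the source reports. "The series", "measured", "known", "first", "only" and "open" are said of these compounds alone.

Working notes on the series built on the shared core of compound 1 `COc1ccccc1Nc1nc(SCc2ccc(C(F)(F)F)cc2)nc2ccccc12`, with three substituents on the nitrogen measured in a functional assay on PC-3 cells (Homo sapiens) for cytotoxicity, read by MTT assay, with a stated time of 72 h; on this read-out lower numbers stand for stronger inhibition and higher numbers for weaker inhibition. Compound 1 gives 14100 nM, compound 2 `Cc1ccccc1Nc1nc(SCc2ccc(C(F)(F)F)cc2)nc2ccccc12` gives 36900 nM, and compound 3 `FC(F)(F)c1ccc(CSc2nc(Nc3cccc(Br)c3)c3ccccc3n2)cc1` gives 8680 nM, the lowest number of the three; the step of a 1.6-fold lower number from compound 1 to compound 3 (0.21 log units; within the scatter) stays within the scatter, whereas a 4.3-fold lower number from compound 2 to compound 3 (0.63 log units; beyond the scatter) lies beyond it. Compound 4 `CCOc1ccc(Nc2nc(SCc3ccc(C(F)(F)F)cc3)nc3ccccc23)cc1` differs from compound 3 by 4-ethoxyphenyl in place of 3-bromophenyl on a nitrogen on an aromatic ring. Among the compounds with values here, the nearest precedent is compound 1, whose 2-methoxyphenyl sits close to compound 3, while the 2-methylphenyl of compound 2 sits further off. Given the step of a 1.6-fold lower number from compound 1 to compound 3 (0.21 log units; within the scatter) from the alkoxy-bearing compound 1, compound 4 is expected to shift by about a 1.4-fold higher number from compound 3 to compound 4 (0.14 log units; within the scatter) in this assay, not beyond the scatter. Compound 4 is estimated at 12000 nM, between 4000 nM and 40000 nM.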

Compound 4, half-maximal inhibitory concentration: 32100 nM
Estimate against measurement, compound 4: 2.7-fold (0.43 log units) below; measured number inside the range.
By their numbers in this assay, from the lowest: compounds 3 and 1 (each within the scatter of the next); then compounds 4 and 2 (each within the scatter of the next).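

In this assay the change to 4-ethoxyphenyl is not neutral on this nitrogen: a 3.7-fold higher number from compound 3 to compound 4 (0.57 log units; beyond the scatter) and a 2.3-fold higher number from compound 1 to compound 4 (0.36 log units; beyond the scatter) both lie beyond the scatter, so sharing an oxygen-linked group does not keep compound 4 with compound 1. Instead, a 1.1-fold lower number from compound 2 to compound 4 (0.06 log units; within the scatter) places 4-ethoxyphenyl with 2-methylphenyl, although the two groups differ in substituent and in where it sits. No evidence bears on these steps.

The compounds shown do not separate the effect of the ethoxy group from that of its place on the ring. Going by these compounds, how an amine, a carboxylic acid or a longer chain on this ring would read also remains open.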